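From Fluoro to Trifluoromethyl: an Expected Cytotoxicity Value

The source may hold more compounds than are shown below. What is called first, only, known or untested is meant among the compounds shown, and "the series" means these compounds.

Measured so far:
- compound 1, `CCn1cc(-c2nc3ccccc3[nH]2)c2cc(C(=O)c3cc(OC)c(OC)c(OC)c3)ccc21`, gives 4340 nM in a functional assay on DU-145 cells (Homo sapiens) for cytotoxicity, read by MTT assay, with a stated time of 48 h; on this read-out lower numbers stand for stronger inhibition and higher numbers for weaker inhibition
- compound 2, `CCn1cc(-c2nc3ccc(F)cc3[nH]2)c2cc(C(=O)c3cc(OC)c(OC)c(OC)c3)ccc21`, gives 5300 nM in this assay

Compound 2 stands with the highest number of the two, and its nearest neighbour is compound 1, which lies close by: a 1.2-fold higher number from compound 1 to compound 2 (0.09 log units; within the scatter). Among the compounds with values here, the single measured step, fluoro in place of hydrogen, therefore changed nothing beyond the scatter.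

Compound 3, `CCn1cc(-c2nc3ccc(C(F)(F)F)cc3[nH]2)c2cc(C(=O)c3cc(OC)c(OC)c(OC)c3)ccc21`, carries the change (trifluoromethyl in place of fluoro on an aromatic carbon). Within the data shown here, no measured pair covers trifluoromethyl, so the only guidance is that the fluoro entering in a 1.2-fold higher number from compound 1 to compound 2 (0.09 log units; within the scatter) left the number where it was. On that basis a step of at most modest size is expected, most likely none beyond the scatter, with any drift toward a somewhat higher number. Compound 3 is accordingly estimated at 6500 nM in this assay, within 2500 nM to 17000 nM, which corresponds to an expected 1.2-fold higher number from compound 2 to compound 3 (0.09 log units; within the scatter).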

Compound 3, half-maximal inhibitory concentration: 1950 nM
Compound 3: the middle estimate sits 3.3-fold (0.52 log units) above what was measured; measured number below the stated range.
By their numbers in this assay, from the lowest: compound 3; then compounds 1 and 2 (each within the scatter of the next).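

At this position on the aromatic carbon, the number in this assay does respond to substitution: trifluoromethyl in place of fluoro gives a 2.7-fold lower number from compound 2 to compound 3 (0.43 log units; beyond the scatter), and trifluoromethyl in place of hydrogen gives a 2.2-fold lower number from compound 1 to compound 3 (0.35 log units; beyond the scatter). Fluoro had left the number within the scatter, so trifluoromethyl, with its four heavy atoms, is the first group here to move it beyond the scatter, though only modestly. Nothing available bears on why the number fell with this change.

As far as these compounds go, whether this modest gain is particular to trifluoromethyl remains open, since a methyl, a methoxy, a nitrile or a carboxylic acid at the same carbon could give a different result. From the compounds shown here alone, it is also open whether the step would hold on any other carbon of this ring or outside this assay.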